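The compounds below may be only part of what the source reports. "The series", "measured", "known", "first", "only" and "open" are said of these compounds alone.

In a functional assay on HeLa cells (Homo sapiens) for cytotoxicity, in the presence of a further agent that is not named here (on this read-out higher numbers stand for weaker inhibition and lower numbers for stronger inhibition), three compounds have been measured so far:
Compound 1 `Clc1ccc(-c2cc(-c3cccs3)nc(-c3ccccc3Cl)c2)o1` gives 18500 nM.
Compound 2 `Clc1ccc(-c2cc(-c3cccnc3)nc(-c3cccs3)c2)o1` gives 14600 nM.
Compound 3 `Clc1ccc(-c2cc(-c3ccc(Cl)o3)cc(-c3cccs3)n2)cc1` gives 21300 nM.

All three numbers lie close together. Compound 1 stands within the scatter of both others: a 1.2-fold higher number from compound 1 to compound 3 (0.06 log units; within the scatter) and a 1.3-fold lower number from compound 1 to compound 2 (0.10 log units; within the scatter). The remaining step, a 1.5-fold higher number from compound 2 to compound 3 (0.16 log units; within the scatter), is also within the scatter. Compound 4 `Clc1ccc(-c2cc(-c3ccsc3)nc(-c3ccccc3Cl)c2)o1` has not yet been measured. It differs from compound 1 in one place (thiophen-3-yl in place of thiophen-2-yl on an aromatic carbon). Within the data shown here, none of the measured steps touches this group: each of them exchanges a different aromatic group on the shared core, and each stayed within the scatter. No step beyond the scatter is therefore expected in this assay from compound 1 to compound 4, so that a 1.0-fold lower number from compound 1 to compound 4 (0.01 log units; within the scatter) is the expected outcome. Compound 4 is estimated at 18000 nM, with a range from 9000 nM to 36000 nM.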

Compound 4, half-maximal inhibitory concentration: 8070 nM
For compound 4 the middle estimate is 2.2-fold (0.35 log units) above the measured one; the measured number lies below the stated range.
By their numbers in this assay, from the lowest: compounds 4, 2, 1 and 3 (each within the scatter of the next, the first and the last beyond it).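

In this assay the group next to the ring nitrogen proves sensitive to a small change: thiophen-3-yl in place of thiophen-2-yl gives a 2.3-fold lower number from compound 1 to compound 4 (0.36 log units; beyond the scatter) although the two compounds hold the same atoms. Among these compounds, this modest step is the first one here beyond the scatter, and it points towards stronger inhibition. Nothing available explains the difference. From the compounds shown here alone, whether the same change helps alongside the pyridin-3-yl or 4-chlorophenyl groups stays open. So does the effect of an amine or a carboxylic acid on the thiophene ring.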